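Adding a methyl to the most potent inhibitor's core

The source may hold more compounds than are shown below. What is called first, only, known or untested is meant among the compounds shown, and "the series" means these compounds.

Of the compounds shown here, three have been tested in an assay on isolated protein for inhibition of S-adenosylmethionine decarboxylase proenzyme (Homo sapiens); on this read-out higher numbers stand for weaker inhibition and lower numbers for stronger inhibition. Compound 1 `Cc1nc2c(N)ncnc2n1[C@@H]1O[C@H](C[S+](C)C)[C@@H](O)[C@H]1O` gives 3000 nM. For the measured compounds named here, compound 2 `Cc1nc2c(N)ncnc2n1[C@@H]1O[C@H](CN(C)CC(=O)NN)[C@@H](O)[C@H]1O` gives 31000 nM; the only measured step in this set, a 10-fold higher number from compound 1 to compound 2 (1.01 log units; beyond the scatter), concerns the side chain and not the core. Compound 3 `CN(CCCCON)C[C@H]1O[C@@H](n2cnc3c(N)ncnc32)[C@H](O)[C@@H]1O` gives 18 nM, the lowest number of the three, far ahead of compound 1 and further still ahead of compound 2.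

Compound 4 `Cc1nc2c(N)ncnc2n1[C@@H]1O[C@H](CN(C)CCCCON)[C@@H](O)[C@H]1O` is not yet measured. It differs from compound 3 by methyl in place of hydrogen on an aromatic carbon; the same methyl is present on the cores of compound 1 and compound 2, while compound 3 lacks it. Going by the values given here, no measured step isolates this methyl, because the three measured compounds also differ in their side chains. The step from compound 1 to compound 2 changed the side chain, so it gives no guidance here. With nothing to suggest a shift, compound 4 is expected to stay close to compound 3, a step of a 1.1-fold higher number from compound 3 to compound 4 (0.05 log units; within the scatter) in this assay. Compound 4 is therefore estimated at 20 nM, within 5 nM to 80 nM.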

Compound 4, half-maximal inhibitory concentration: 5 nM
Beside the measured number, compound 4's estimate is 4.0-fold (0.60 log units) above it; low and high end bracket the measured number.
By their numbers in this assay, from the lowest: compound 4; then compound 3; then compound 1; then compound 2.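

The methyl on the aromatic carbon between two ring nitrogen atoms now has a step of its own: with the side chain unchanged, replacing hydrogen gives a 3.6-fold lower number from compound 3 to compound 4 (0.56 log units; beyond the scatter), a modest change but one beyond the scatter. With the methyl-bearing core unchanged, the side chain has a far larger effect: 3-(aminooxy)propyl in place of aminocarbamoyl gives a 6200-fold lower number from compound 2 to compound 4 (3.79 log units; beyond the scatter), and exchanging the whole side chain gives a 600-fold lower number from compound 1 to compound 4 (2.78 log units; beyond the scatter). This position therefore accepts a methyl alongside the aminooxy chain, and the gain is small beside these side-chain steps.

Nothing shown explains why this methyl lowers the number. On these data alone, whether an ethyl or an amine at this position would do better, and whether the methyl gives a similar gain with other side chains, remains open.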